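Propyl to cyclohexyl at the limit of the assay

The source may hold more compounds than are shown below. What is called first, only, known or untested is meant among the compounds shown, and "the series" means these compounds.

Compound 1 `COc1cc(/C=C/C(=O)/C=C(/C=C/c2ccc(OC(C)=O)c(OC)c2)NC2CCCCC2)ccc1OC(C)=O` gives > 25000 nM as a limit
Compound 2 `CCCNC(=C\C(=O)/C=C/c1ccc(O)c(OC)c1)/C=C/c1ccc(O)c(OC)c1` gives > 25000 nM as a limit
Compound 3 `COc1cc(/C=C/C(=O)CC(=O)/C=C/c2ccc(OC(C)=O)c(OC)c2)ccc1OC(C)=O` gives > 25000 nM as a limit

In an ADME assay on Caco-2 cells (Homo sapiens) for inhibition, read by MTT assay, with a stated time of 72 h (a lower number here means a stronger inhibitor, a higher number a weaker inhibitor), these three compounds share one result (the limit of > 25000 nM in this assay, at which 3 of the 3 values shown sit) and each entry is a limit, not a number. The read-out is a concentration, so a number here would show how strongly that compound inhibits.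

Compound 2 has only a limit (> 25000 nM) to mark its place in this assay and no number.

Compound 4 `COc1cc(/C=C/C(=O)/C=C(/C=C/c2ccc(O)c(OC)c2)NC2CCCCC2)ccc1O` has not been measured yet. Compared with compound 2 it carries one change (cyclohexyl in place of propyl on an amine nitrogen) that in words is cyclohexyl in place of propyl on an amine nitrogen. Among the compounds with values here, no pair of measured compounds shows a step of this kind, so its size has to be judged without a direct example.

Compound 1 also carries cyclohexyl on an amine nitrogen and gives > 25000 nM as a limit. In this assay no clear shift in either direction is therefore expected. The expected change is a number no higher from compound 2 to compound 4 (the limit leaves the size open) and that lies within the scatter. For compound 4 the estimated value is 25000 nM with 10000 nM to 50000 nM as the expected range, and another limit would be no surprise.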

Compound 4, half-maximal inhibitory concentration: > 25000 nM
Compound 4 ended at the assay's limit; the forecaster's own chance of this, stated with the estimate: 60%; the middle value lies on the limit itself.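

Compound 2 and compound 4 both end at a limit of this assay rather than at a number, so cyclohexyl in place of propyl on an amine nitrogen gives no step that can be read: the limit of > 25000 nM in this assay, at which 4 of the 4 values shown sit.

The compounds shown leave open how strongly any of them inhibits in this assay, and whether this change alters inhibition at all.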